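The compounds below may be only part of what the source reports. "The series", "measured", "known", "first", "only" and "open" are said of these compounds alone.

In a functional assay on K562 cells (Homo sapiens) for antiproliferative activity, read by MTT assay, with a stated time of 72 h (a higher number here means a weaker inhibitor, a lower number a stronger inhibitor), compound 1 (`COc1cc(-c2ncnn2-c2cccc(N)c2)cc(OC)c1OC`) gives > 10000 nM, which is a limit of the assay. Compound 2 (`COc1cc(-c2ncnn2-c2ccc(F)cc2)cc(OC)c1OC`) gives > 10000 nM, also a limit. Compound 2 therefore has no number of its own, only (the limit of > 10000 nM in this assay, at which 2 of the 2 values shown sit). Compound 3 (`COc1cc(-c2ncnn2-c2ccc([N+](=O)[O-])cc2)cc(OC)c1OC`) differs from it by nitro in place of fluoro on an aromatic carbon, with nitro in place of fluoro on an aromatic carbon. For the measured compounds named here, the only measured step, a step that the two limits leave unreadable from compound 1 to compound 2, has no size to carry over, so no step beyond the scatter can be expected in this assay. The estimated change is a step that the limit leaves unreadable from compound 2 to compound 3. Compound 3 is expected at about 12000 nM, within a range of 3000 nM to 30000 nM.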

Compound 3, half-maximal inhibitory concentration: > 10000 nM
Compound 3 was reported as a limit; the forecaster's own chance of this, stated with the estimate: 75%; the middle value is on the limit's open side.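

Compound 2 and compound 3 are both reported only as limits, so no step between them can be read: the limit of > 10000 nM in this assay, at which 3 of the 3 values shown sit.

The compounds shown leave open how strong any of the three really is, and whether exchanging these groups changes the activity at all.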